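Replacing the indole of compound 2 with a fluorophenyl ring

This account rests on a few compounds, and the source may have more. Where it says the series, first, only, none or still open, it means among the compounds named here.

Measured compounds:
- compound 1 `COc1ccc2c(OCc3nnc4sc(-c5cnn(C)c5)nn34)ccnc2c1`: 88 nM
- compound 2 `COc1ccc2c(OCc3nnc4sc(-c5cc6cc(F)ccc6[nH]5)nn34)ccnc2c1`: "not determined" (no result reported)

In a functional assay on EBC-1 cells (Homo sapiens) for antiproliferative activity, with a stated time of 72 h (on this read-out higher numbers stand for weaker inhibition and lower numbers for stronger inhibition), compound 1 gives 88 nM. Compound 2 was run in the same series but gives only "not determined" (no result reported) in this assay, so where it stands cannot be told; the only fixed point on this read-out is compound 1.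

Compound 3 `COc1ccc2c(OCc3nnc4sc(-c5cccc(F)c5)nn34)ccnc2c1` differs from compound 2 in one place: 3-fluorophenyl in place of 5-fluoro-1H-indol-2-yl on an aromatic carbon. Within the data shown here, because compound 2 has no value, no step from compound 2 to compound 3 can be given, and its size and direction remain open. What can be said rests on compound 1, which shares the core of compound 3 and differs from it only in the group on the same aromatic carbon. An aryl group of the kind that enters compound 3 is expected to keep the series within the range set by compound 1, with no step beyond the scatter foreseen in either direction.

In this assay compound 3 is therefore estimated at 60 nM, within 15 nM to 300 nM.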

Compound 3, half-maximal inhibitory concentration: 504 nM
Compound 3: middle estimate off by 8.4-fold (0.92 log units), on the low side; the whole stated range lies below it.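

In this assay the group on this aromatic carbon proves able to move the read-out: 3-fluorophenyl in place of 1-methyl-1H-pyrazol-4-yl gives a 5.7-fold higher number from compound 1 to compound 3 (0.76 log units; beyond the scatter) and so takes the series to weaker inhibition by more than the usual scatter, which compound 1 alone, as the only fixed point, could not show. This is a single exchange of one aromatic ring for another on the shared core, and it shows that the two rings are not interchangeable at this place, though it is a modest step and the compound keeps a measurable value. Compound 2 has no value, so the step from it to compound 3 cannot be read, and nothing in the data given explains the difference between compound 1 and compound 3.

The compounds shown do not separate the part played by the fluorine of compound 3 from that of the phenyl ring that carries it, which an unsubstituted phenyl would address. They also leave open how this position would respond to a group of another kind, such as an amine like morpholine or a carboxylic acid.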